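Fluoro for methyl on the sulfonamide ring: second pair

A few compounds are considered here, and "the series" means these few. Any claim that something is new, unique, unknown or untested is made for them only; others in the source may bear on it.

Compound 1 `Cc1ccc(S(=O)(=O)NC(=O)/C=C/c2ccc([N+](=O)[O-])cc2)cc1` and compound 2 `O=C(/C=C/c1ccc([N+](=O)[O-])cc1)NS(=O)(=O)c1ccc(F)cc1` share one core; compound 2 differs from compound 1 by fluoro in place of methyl on an aromatic carbon. In a functional assay on B16-F10 cells (Mus musculus) for antiproliferative activity, read by ELISA and MTT assay, with a stated time of 48 h (on this read-out higher numbers stand for weaker inhibition and lower numbers for stronger inhibition), compound 1 gives 13.5 ug/mL, and compound 2 gives 2.2 ug/mL. That is a 6.1-fold lower number from compound 1 to compound 2 (0.79 log units; beyond the scatter). Compound 3 `Cc1ccc(S(=O)(=O)NC(=O)/C=C/c2ccccc2[N+](=O)[O-])cc1` holds the same atoms as compound 1 joined differently; how the two cores differ is not broken down here. In this assay compound 3 gives 10.3 ug/mL, a number that sits close to that of compound 1 and well apart from that of compound 2. Compound 4 `O=C(/C=C/c1ccccc1[N+](=O)[O-])NS(=O)(=O)c1ccc(F)cc1` is not yet measured and differs from compound 3 by fluoro in place of methyl on an aromatic carbon, the same change that carried compound 1 to compound 2, at the same place. The step expected for compound 4 is a 3.0-fold lower number from compound 3 to compound 4 (0.48 log units; beyond the scatter). Among the measured compounds shown here, this rests on the one measured instance of the change, a 6.1-fold lower number from compound 1 to compound 2 (0.79 log units; beyond the scatter), taken somewhat smaller since it comes from a single pair and the core of compound 3 is another. On that basis compound 4 is estimated at 3.4 ug/mL in this assay, expected to fall between 1.3 ug/mL and 8.5 ug/mL.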

Compound 4, half-maximal inhibitory concentration: 6 ug/mL
The estimate for compound 4 lay 1.8-fold (0.25 log units) below the measured number, within the range that was stated.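

In this assay, the change from 4-methylphenyl to 4-fluorophenyl on the core of compound 3 gives a 1.7-fold lower number from compound 3 to compound 4 (0.23 log units; within the scatter), so the larger step seen on the core of compound 1 does not carry over at full size. The size of this change differs between the two cores, and the gap between the two steps is larger than scatter alone would give: the same change on two cores in this assay, a 6.1-fold lower number (0.79 log units; beyond the scatter) from compound 1 to compound 2 and a 1.7-fold lower number (0.23 log units; within the scatter) from compound 3 to compound 4, 3.6-fold (0.55 log units) apart, beyond the scatter of two such steps This shows that a step measured on one core of this series was a poor guide to its size on the other, but it does not show what in the cores sets the difference, and two pairs give no rule for any further core.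

The compounds shown leave open how other groups in place of the fluoro, such as chloro, methoxy or trifluoromethyl, would behave on either core. They also leave open whether the gap between the two steps would persist if the nitro group were replaced by an amine or a nitrile.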